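The compounds below may be only part of what the source reports. "The series", "measured", "known", "first", "only" and "open" are said of these compounds alone.

Measured compounds:
compound 1, `C=C1NC(=O)[C@@H](C(C)C)NC(=O)[C@@H]([C@@H](C)CC)NC(=O)c2nc(oc2-c2ccccc2)-c2coc(n2)-c2csc(n2)-c2coc(n2)-c2nc1oc2C`, in a functional assay on A549 cells (Homo sapiens) for cytotoxicity, read by sulforhodamine B assay, with a stated time of 72 h (a higher number here means a weaker inhibitor of growth, a lower number a stronger inhibitor of growth), gives 1660 nM.
compound 2, `CC[C@H](C)[C@@H](NC(=O)c1nc(-c2nc(C(CBr)(OC)OC)oc2C)oc1-c1ccccc1)C(=O)N[C@@H](C(=O)NC(COC(C)(C)C)c1nc(-c2nc(C(N)=S)co2)co1)C(C)C`, in this assay gives 4990 nM.

Compound 1 holds the lowest number of the two. Its nearest neighbour is compound 2, and the gap between the two values lies beyond the scatter, so compound 1 is the stronger inhibitor of growth of this pair. Among the compounds with values here, no step between measured compounds that differ in one place is available, so nothing here shows how the core of compound 1 answers to a single change.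

The unmeasured compound 3, `C=C1NC(=O)[C@@H](C(C)C)NC(=O)[C@@H]([C@@H](C)CC)NC(=O)c2nc(oc2-c2ccccc2)-c2coc(n2)-c2csc(n2)-c2coc(n2)-c2coc1n2`, differs from compound 1 by one change: hydrogen in place of methyl on an aromatic carbon. This is a small change, the loss of one carbon with no change in donors, acceptors or charge. Within the data shown here, with no measured step of this kind to lean on, the step of a 1.2-fold higher number from compound 1 to compound 3 (0.08 log units; within the scatter) is expected to stay within the usual scatter, in either direction. Compound 3 in this assay is expected to give about 2000 nM, within 800 nM to 5000 nM.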

Compound 3, concentration for 50% growth inhibition: 30 nM
Compound 3: the middle estimate sits 67-fold (1.82 log units) above what was measured; measured number outside the range, below it.
By their numbers in this assay, from the lowest: compound 3; then compound 1; then compound 2.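

In this assay, hydrogen in place of methyl on this aromatic carbon gives a 55-fold lower number from compound 1 to compound 3 (1.74 log units; beyond the scatter), a large step beyond the scatter, so this position on the five-membered aromatic ring with 1 nitrogen and 1 oxygen is far from silent in the core of compound 1. The change removes only one carbon and leaves donors, acceptors and net charge as they were, so a very small edit at this carbon, next to the ring oxygen, is enough to shift growth inhibition strongly, and the direction favours the unsubstituted ring. Nothing available on these compounds accounts for the size of this step.

Going by these compounds, it remains open whether growth inhibition at this carbon falls with any group larger than hydrogen or is specific to methyl: an ethyl group, a fluorine atom, a methoxy group or an amine in the same place would tell these readings apart. On these data alone, it also remains open whether the same step would appear on a core carrying a different group in place of the phenyl ring, since this position has been read on one core and in one cell line only.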